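From compound 3 to compound 4: an acetoxy swap

A few compounds are considered here, and "the series" means these few. Any claim that something is new, unique, unknown or untested is made for them only; others in the source may bear on it.

Values so far in an ADME assay on Vero cells (Chlorocebus sabaeus) for cytotoxicity, read by MTT assay, with a stated time of 48 h (a higher number here means a weaker inhibitor, a lower number a stronger inhibitor), are:
Compound 1 (`Cc1cccc(C(=O)OC2CCC(CN3CCN(c4cc(=O)c5cc(C(F)(F)F)cc([N+](=O)[O-])c5s4)CC3)CC2)c1`) gives > 64 ug/mL as a limit
Compound 2 (`CS(=O)(=O)NC1CCC(CN2CCN(c3cc(=O)c4cc(C(F)(F)F)cc([N+](=O)[O-])c4s3)CC2)CC1`) gives 48.5 ug/mL as a number
Compound 3 (`O=c1cc(N2CCN(CC3CCC(NS(=O)(=O)c4ccccc4)CC3)CC2)sc2c([N+](=O)[O-])cc(C(F)(F)F)cc12`) gives > 64 ug/mL as a limit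

Compound 3 has no exact number, only a limit, and compound 1 shares that limit (the limit of > 64 ug/mL in this assay, at which 2 of the 3 values shown sit). Compound 4 (`CC(=O)OC1CCC(CN2CCN(c3cc(=O)c4cc(C(F)(F)F)cc([N+](=O)[O-])c4s3)CC2)CC1`) has acetoxy in place of (phenylsulfonyl)amino on a saturated ring carbon. Going by the values given here, no measured step makes exactly this swap, but three measured steps change the group on that same carbon. One shows an at least 1.3-fold lower number from compound 1 to compound 2 (0.12 log units; that floor lies within the scatter) for methanesulfonamido, a second shows an at least 1.3-fold higher number from compound 2 to compound 3 (0.12 log units; that floor lies within the scatter) for phenyl in place of methyl, and the third shows a step that the two limits leave unreadable from compound 1 to compound 3 for (phenylsulfonyl)amino. None of the three is shown to lie beyond the scatter, and compound 2 at 48.5 ug/mL is the only exact number in the set. No step beyond the scatter is therefore expected in this assay in either direction. This estimate means an at least 1.0-fold lower number from compound 3 to compound 4 (0.02 log units; that floor lies within the scatter) as the expected step. For compound 4 the estimated value is 60 ug/mL with an expected range of 30 ug/mL to 120 ug/mL and a real chance of only a limit.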

Compound 4, half-maximal inhibitory concentration: > 64 ug/mL
Compound 4 was reported as a limit; the forecaster's own chance of this, stated with the estimate: 50%; at least 1.0-fold (0.02 log units) between middle value and limit.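

In this assay, acetoxy, a group with no ring and no hydrogen-bond donor, now sits at the same limit on the saturated ring carbon as ((3-methylphenyl)carbonyl)oxy and (phenylsulfonyl)amino, so a ring in this group is not needed to reach that limit: the limit of > 64 ug/mL in this assay, at which 3 of the 4 values shown sit. The only readable new comparison is an at least 1.3-fold higher number from compound 2 to compound 4 (0.12 log units; that floor lies within the scatter), so acetoxy is not shown to differ from methanesulfonamido, the one group here with an exact number. The steps from compound 1 and compound 3 to compound 4 cannot be read, as both compounds in each pair are reported only as limits.

The compounds shown therefore leave open whether any change at this carbon moves the number beyond the scatter, and how far apart compound 1, compound 3 and compound 4 really lie. A basic amine, a carboxylic acid or a plain hydroxyl on the same carbon, each measured in this assay as an exact number, would show whether this position matters for the read-out at all.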